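Removing one methoxy group from the aryl ketone of compound 3

A few compounds are considered here, and "the series" means these few. Any claim that something is new, unique, unknown or untested is made for them only; others in the source may bear on it.

Measured so far:
compound 1 `COc1cc(-c2cc(/C=C/C(=O)c3ccc(N)cc3)[nH]n2)cc(OC)c1OC` gives 70%
compound 2 `COc1cc(-c2cc(/C=C/C(=O)c3ccc(Cl)c(Cl)c3)[nH]n2)cc(OC)c1OC` gives 89%
compound 3 `COc1ccc(C(=O)/C=C/c2cc(-c3cc(OC)c(OC)c(OC)c3)n[nH]2)cc1OC` gives 77%

In a functional assay on MDA-MB-231 cells (Homo sapiens) for cytotoxicity, read by sulforhodamine B assay, with a stated time of 48 h, tested at 1 uM (a higher number here means a weaker effect of the compound at the concentration tested, a lower number a stronger effect), compound 3 stands second highest of the three numbers: its nearest neighbour is compound 1, a difference within the scatter, and the furthest is compound 2, whose number is higher beyond the scatter (a number 12 percentage points lower from compound 2 to compound 3 (beyond the scatter)). The step from compound 1 to compound 3 was a number 7 percentage points higher from compound 1 to compound 3 (within the scatter), and the step from compound 1 to compound 2 was a number 19 percentage points higher from compound 1 to compound 2 (beyond the scatter).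

Compound 4 `COc1ccc(C(=O)/C=C/c2cc(-c3cc(OC)c(OC)c(OC)c3)n[nH]2)cc1` differs from compound 3 by hydrogen in place of methoxy on an aromatic carbon. Among the compounds with values here, none of the measured steps removes a single methoxy group; each of them swaps the whole aryl ring on the carbonyl carbon, and even those swaps moved this assay by only modest amounts. Because the measured step of a number 7 percentage points higher from compound 1 to compound 3 (within the scatter) was within the scatter, the expected step of a number 1 percentage points higher from compound 3 to compound 4 (within the scatter) is likewise small, with no clear direction. Compound 4 is therefore estimated to give 78% in this assay, within a range from 62% to 92%.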

Compound 4, a percentage reported as activity, at one concentration (the size of the read-out at that concentration, not a potency): 81%
Beside the measured number, compound 4's estimate is 3 percentage points below it, within the range that was stated.
By their numbers in this assay, from the lowest: compounds 1, 3, 4 and 2 (each within the scatter of the next, the first and the last beyond it).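

In this assay, the step that removes a single methoxy group rather than swapping the whole aryl ring (a number 4 percentage points higher from compound 3 to compound 4 (within the scatter)) shows that the 3,4-dimethoxyphenyl and 4-methoxyphenyl ketones cannot be told apart at this position. The 4-methoxyphenyl ketone also cannot be told apart from the 3,4-dichlorophenyl ketone (a number 8 percentage points lower from compound 2 to compound 4 (within the scatter)), whereas it does separate from the 4-aminophenyl ketone (a number 11 percentage points higher from compound 1 to compound 4 (beyond the scatter)), so among these steps from compound 4, only the one involving compound 1 exceeds the scatter. Nothing available here accounts for these steps.

The compounds shown leave open whether removing the remaining methoxy group, or replacing it with a hydroxyl or a dimethylamino group, would move the number. They also leave open whether these small steps in the size of the effect at a single concentration would hold at any other concentration.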